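Cytotoxicity on fibroblasts across a shared-core series

This account rests on a few compounds, and the source may have more. Where it says the series, first, only, none or still open, it means among the compounds named here.

Measured in an ADME assay on BJ cells (Homo sapiens) for cytotoxicity, with a stated time of 72 h; on this read-out higher numbers stand for an effect only at larger amounts of compound and lower numbers for an effect already at smaller amounts:
compound 1 `C=C[C@@](C)(/C=C/c1ccc(OCc2ccccc2)cc1)CCC=C(C)C` gives > 36600 nM, a limit of the assay.
compound 2 `C=C[C@@](C)(/C=C/c1ccc(O)c(/C=C(\C)C(=O)OCC)c1)CCC=C(C)C` gives > 36600 nM, a limit of the assay.
compound 3 `CC(C)=CCC[C@](C)(/C=C/c1ccc(O)cc1)/C=C/c1cccc(Cl)c1` gives > 36600 nM, a limit of the assay.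

Compound 1 stands at a limit only, with no number behind it, and the two other values shown are limits as well, as the limit of > 36600 nM in this assay, at which 3 of the 3 values shown sit, records. For the measured compounds named here, no step between measured compounds can be drawn, so this assay does not separate the three.

Compound 4 `C=C[C@@](C)(/C=C/c1ccc(Nc2ccc(Cl)cc2)cc1)CCC=C(C)C` is still unmeasured. It differs from compound 1 in one place: (4-chlorophenyl)amino in place of benzyloxy on an aromatic carbon. Because the limit of > 36600 nM in this assay, at which 3 of the 3 values shown sit, holds for every value shown, no step beyond the scatter is expected from compound 1 to compound 4, and the expected step is a number no higher from compound 1 to compound 4 (the limit leaves the size open). Compound 4 is therefore estimated at 36600 nM, with a range from 15000 nM to 90000 nM, most likely reported again only as a limit.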

Compound 4, half-maximal effective concentration: > 36600 nM
Compound 4: a limit, no number; the forecaster's own chance of this, stated with the estimate: 75%; the middle value lies on the limit itself.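

Compound 4 gives > 36600 nM, again a limit of the assay. For the compounds shown here, compound 1 also stands at a limit, and no step from compound 1 to compound 4 can be read. The compounds shown leave open at what concentration any of them would affect these cells.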